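Replacing 3-hydroxyphenyl with 4-methoxyphenyl on an amide-type nitrogen

This account rests on a few compounds, and the source may have more. Where it says the series, first, only, none or still open, it means among the compounds named here.

Among the compounds with values here, in a functional assay on T47D cells (Homo sapiens) for inhibition, read by CCK-8 assay, with a stated time of 72 h, tested at 1 uM (on this read-out higher numbers stand for more inhibition of growth at the one concentration tested and lower numbers for less inhibition of growth), compound 3 `CN(C)C(=O)c1cc2cnc(Nc3ccc(NC(=O)C4(C(=O)Nc5cccc(O)c5)CC4)cc3)nc2n1C1CCCC1` gives 80.7%, the highest of the three numbers so far. Compound 1 `CN(C)C(=O)c1cc2cnc(Nc3ccc(NC(=O)C4(C(=O)Nc5ccc(Cl)cc5)CC4)cc3)nc2n1C1CCCC1` gives 22.8%, and compound 2 `CN(C)C(=O)c1cc2cnc(Nc3ccc(NC(=O)C4(C(=O)Nc5cccc(F)c5)CC4)cc3)nc2n1C1CCCC1` gives -3.2%.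

The structural change under study leads to compound 4 `COc1ccc(NC(=O)C2(C(=O)Nc3ccc(Nc4ncc5cc(C(=O)N(C)C)n(C6CCCC6)c5n4)cc3)CC2)cc1`: 4-methoxyphenyl in place of 3-hydroxyphenyl on an amide-type nitrogen.

Within the data shown here, three measured steps bear on this change. The two that reach the 3-hydroxyphenyl compound are both large: a number 57.9 percentage points higher from compound 1 to compound 3 (beyond the scatter) and a number 83.9 percentage points higher from compound 2 to compound 3 (beyond the scatter). The step between the two compounds without the hydroxy group is modest: a number 26 percentage points lower from compound 1 to compound 2 (beyond the scatter). Among the measured compounds shown here, no measured compound carries 4-methoxyphenyl, so any expectation is indirect. The nearest guide is compound 1, whose 4-chlorophenyl group gives 22.8%, while the loss of the hydroxy group in compound 2 goes with a number 83.9 percentage points higher from compound 2 to compound 3 (beyond the scatter), read in reverse.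

A large downward step is therefore expected, estimated as a number 45.7 percentage points lower from compound 3 to compound 4 (beyond the scatter).

For compound 4 the expected value is 35%, with an estimated range from 5% to 70%.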

Compound 4, percent growth inhibition at one concentration: 76.4%
Beside the measured number, compound 4's estimate is 41.4 percentage points below it; measured number outside the range, above it.
By their numbers in this assay, from the lowest: compound 2; then compound 1; then compounds 4 and 3 (each within the scatter of the next).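

In this assay a hydrogen-bond donor on the aryl group at this amide-type nitrogen is not required for a high number, since 4-methoxyphenyl, with 0 hydrogen-bond donors, stands level with 3-hydroxyphenyl: a number 4.3 percentage points lower from compound 3 to compound 4 (within the scatter). Across the four compounds, with none going against it, the two oxygen-bearing aryl groups stand above the two halogen-bearing ones, as a number 79.6 percentage points higher from compound 2 to compound 4 (beyond the scatter) and a number 53.6 percentage points higher from compound 1 to compound 4 (beyond the scatter) show, the latter being methoxy in place of chloro on an aromatic carbon. No supporting data bear on why this is so.

As far as these compounds go, because the step to compound 4 changes both the group and its place on the ring, the contribution of each remains open. From the compounds shown here alone, whether an unsubstituted phenyl or an aminophenyl group would stand with the oxygen-bearing or the halogen-bearing compounds is also open.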